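A few compounds are considered here, and "the series" means these few. Any claim that something is new, unique, unknown or untested is made for them only; others in the source may bear on it.

Series notes, measured so far in a functional assay on LOX IMVI cells (Homo sapiens) for cytotoxicity, read by MTT assay, with a stated time of 24 h; on this read-out lower numbers stand for stronger inhibition and higher numbers for weaker inhibition:
- compound 1 `COc1cc(-c2nc(-c3ccccc3)[nH]c2-c2ccnc(NCCCNS(=O)(=O)c3ccc(C(F)(F)F)cc3)n2)ccc1Cl` gives 1780 nM
- compound 2 `O=S(=O)(NCCCNc1nccc(-c2[nH]c(-c3ccccc3)nc2-c2ccc(F)c(O)c2)n1)c1ccc(Br)cc1` gives 5660 nM

Of these two numbers, compound 2 has the higher, 5660 nM, and so the weaker inhibition in this assay. Compound 1 stands lower at 1780 nM, a gap beyond the scatter.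

Next in line is compound 3 `O=S(=O)(NCCCNc1nccc(-c2[nH]c(-c3ccccc3)nc2-c2ccc(F)c(O)c2)n1)c1ccc(C(F)(F)F)cc1`, not yet measured. It departs from compound 2 by trifluoromethyl in place of bromo on an aromatic carbon, para to a large group, the change from 4-bromophenyl to 4-(trifluoromethyl)phenyl: trifluoromethyl in place of bromo on an aromatic carbon.

For the measured compounds named here, no single-place step between measured compounds is available to size this change. Going by the values given here, the only hint is compound 1, which carries the 4-(trifluoromethyl)phenyl group and gives 1780 nM. However, it also differs from compound 2 elsewhere, so the gap cannot be assigned to this group alone. A small move toward a lower number is expected, but none beyond the scatter. The expected step is a 1.4-fold lower number from compound 2 to compound 3 (0.15 log units; within the scatter). For compound 3 the estimated value is 4000 nM, with an expected range of 1800 nM to 9000 nM.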

Compound 3, half-maximal inhibitory concentration: 2450 nM
The estimate for compound 3 lay 1.6-fold (0.21 log units) above the measured number; the measured number falls inside the stated range.
By their numbers in this assay, from the lowest: compounds 1 and 3 (each within the scatter of the next); then compound 2.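

In this assay the change from 4-bromophenyl to 4-(trifluoromethyl)phenyl now has a direct size, a 2.3-fold lower number from compound 2 to compound 3 (0.36 log units; beyond the scatter), so the group on this aromatic carbon does move the number, though modestly, with the rest of compound 2 held fixed. With the 4-(trifluoromethyl)phenyl group held fixed instead, 4-fluoro-3-hydroxyphenyl in place of 4-chloro-3-methoxyphenyl gives a 1.4-fold higher number from compound 1 to compound 3 (0.14 log units; within the scatter), so this second exchange shows no change that can be told from the scatter. No supporting data bear on the cause of either step.

Whether the step from bromo to trifluoromethyl keeps its size with the 4-chloro-3-methoxyphenyl group in place remains open, since the compounds shown offer only one such pair, and one pair sets no trend for the series. Also open, as far as these compounds go, is how this aromatic carbon responds to other groups, such as a nitrile, an amine or a carboxylic acid, and whether a longer chain in the linker would shift the number in this assay.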